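Adding methoxy groups to the aryl ring of compound 3

A few compounds are considered here, and "the series" means these few. Any claim that something is new, unique, unknown or untested is made for them only; others in the source may bear on it.

In a functional assay on A549 cells (Homo sapiens) for inhibition, read by MTT assay, with a stated time of 48 h (a lower number here means a stronger inhibitor of growth, a higher number a weaker inhibitor of growth), compound 1 (`COc1ccc2c(c1)c(C1CC(c3ccc(F)cc3)=NN1C(=O)c1ccc(OC)nc1)cn2C`), which carries a fluoro group on its aromatic ring, gives 710 nM as its reading. Compound 2 (`COc1ccc2c(c1)c(C1CC(c3ccc(Cl)cc3)=NN1C(=O)c1ccc(OC)nc1)cn2C`), the chloro counterpart, gives 3390 nM in the same test, and compound 3 (`COc1ccc(C2=NN(C(=O)c3ccc(OC)nc3)C(c3cn(C)c4ccc(OC)cc34)C2)cc1`), the methoxy counterpart, gives 450 nM there. Compound 3 has the lowest of these numbers, yet the data show a 1.6-fold lower number from compound 1 to compound 3 (0.20 log units; within the scatter) and therefore do not separate it from compound 1. Compound 2 stands apart, with a 4.8-fold higher number from compound 1 to compound 2 (0.68 log units; beyond the scatter) and a 7.5-fold lower number from compound 2 to compound 3 (0.88 log units; beyond the scatter) on record.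

Compound 4 (`COc1ccc2c(c1)c(C1CC(c3cc(OC)c(OC)c(OC)c3)=NN1C(=O)c1ccc(OC)nc1)cn2C`) has 3,4,5-trimethoxyphenyl in place of 4-methoxyphenyl on a carbon with a double bond to nitrogen. The three measured steps all exchange one group on this aromatic ring, and none adds further methoxy groups, so they bear on the change only indirectly. Their largest, a 7.5-fold lower number from compound 2 to compound 3 (0.88 log units; beyond the scatter), shows that the series can move modestly in either direction, which sets the width of the range. No direction is favoured, so the expectation is a 1.1-fold lower number from compound 3 to compound 4 (0.05 log units; within the scatter) with no shift beyond the scatter foreseen. Compound 4 is estimated at 400 nM with an expected range from 110 nM to 1700 nM (an estimate).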

Compound 4, concentration for 50% growth inhibition: > 10000 nM
Compound 4: a limit, no number (the forecaster's own chance of this, stated with the estimate: 3%); at least 25-fold (1.39 log units) between middle value and limit.
By their numbers in this assay, from the lowest: compounds 3 and 1 (each within the scatter of the next); then compound 2. At a limit, above all of these: compound 4.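

Compound 4 gives no number in this assay, only a limit of the assay: the limit of > 10000 nM in this assay, at which 1 of the 4 values shown sits.

The earlier exchanges of one group on this aromatic ring were modest at most, whereas the step to 3,4,5-trimethoxyphenyl, on the carbon with a double bond to nitrogen, is large: an at least 22-fold higher number from compound 3 to compound 4 (1.34 log units; beyond the scatter) and an at least 14-fold higher number from compound 1 to compound 4 (1.14 log units; beyond the scatter). Compound 2, which had the highest number of the earlier three, is also passed, with an at least 2.9-fold higher number from compound 2 to compound 4 (0.46 log units; beyond the scatter), so the presence of a methoxy group at this place does not by itself keep the low numbers seen with the 4-methoxyphenyl group.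

The compounds shown do not tell whether a single added methoxy group is enough for this loss, since neither a 3,4-dimethoxyphenyl nor a 3-methoxyphenyl counterpart stands among them, and they say nothing of an amine or a carboxylic acid on this ring. As the reading of compound 4 is a limit, the true size of all three steps also remains open, and the data give no cause for them.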